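The source may report more compounds than this note shows. Statements on the series, on what has been measured and on what is new or still open speak of the compounds shown alone.

For the measured compounds named here, in a functional assay on K562 cells (Homo sapiens) for inhibition, read by fluorescence and resazurin assay, with a stated time of 72 h (on this read-out lower numbers stand for stronger inhibition of growth and higher numbers for weaker inhibition of growth), compound 1 (`Nc1ccccc1-c1ccc(Nc2nc(N[C@H]3CC[C@H](N)CC3)nc3c2ncn3C2CCCC2)cc1`) gives 1070 nM and so holds the higher of the two numbers known so far, while compound 2 (`N[C@H]1CC[C@H](Nc2nc(Nc3ccc(-c4ccccc4O)nc3)c3ncn(C4CCCC4)c3n2)CC1`) gives 500 nM as the lower one. Compound 2 differs from compound 1 in more than one place, so their values cannot be tied to a single change. Compound 3 (`N[C@H]1CC[C@H](Nc2nc(Nc3ccc(Oc4ccc(Br)cn4)cc3)c3ncn(C4CCCC4)c3n2)CC1`) is still unmeasured. Compared with compound 1, it carries (5-bromopyridin-2-yl)oxy in place of 2-aminophenyl on an aromatic carbon on the shared core. Expected here is a 1.3-fold lower number from compound 1 to compound 3 (0.13 log units; within the scatter) as a small move toward a lower number that stays within the scatter. The estimate for compound 3 is 800 nM as the expected middle, with 250 nM to 2500 nM as its range.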

Compound 3, concentration for 50% growth inhibition: 6080 nM
Estimate against measurement, compound 3: 7.6-fold (0.88 log units) below; the measured number lies above the stated range.
By their numbers in this assay, from the lowest: compound 2; then compound 1; then compound 3.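

In this assay, putting (5-bromopyridin-2-yl)oxy in place of 2-aminophenyl on this aromatic carbon gives a 5.7-fold higher number from compound 1 to compound 3 (0.75 log units; beyond the scatter), which means weaker inhibition of growth. The position is therefore not indifferent to the group it carries, and this exchange costs activity. Nothing available explains the loss.

The oxygen, the ring nitrogen and the bromine all enter together, so the step cannot be assigned to any one of them. Going by these compounds, how a plain phenoxy group would behave on this carbon remains open.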